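This account rests on a few compounds, and the source may have more. Where it says the series, first, only, none or still open, it means among the compounds named here.

Measured compounds:
Compound 1, `CS(=O)(=O)Oc1c(C(=O)NCc2ccc(F)cc2)nc(Br)c2cccnc12`, in a functional assay on MDA-MB-435 cells (Homo sapiens) for cytotoxicity, read by MTT assay, with a stated time of 72 h (a lower number here means a stronger inhibitor, a higher number a weaker inhibitor), gives > 20000 nM.
Compound 2, `O=C(NCc1ccc(F)cc1)c1nc(Br)c2cccnc2c1NCCCNc1c(C(=O)NCc2ccc(F)cc2)nc(Br)c2cccnc12`, gives > 20000 nM.
Compound 3, `CN(C)c1ccc(CNC(=O)c2nc(Br)c3cccnc3c2N[C@H]2CC[C@H](N)CC2)cc1`, gives 4000 nM.

The value for compound 1 is a limit of the assay, not a number. The value for compound 2 is likewise a limit. Only compound 3 gives an actual number, and compound 1 sits at the limit of > 20000 nM in this assay, at which 2 of the 3 values shown sit.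

Compound 4, `C[C@H](Nc1c(C(=O)NCc2ccc(F)cc2)nc(Br)c2cccnc12)c1ccccc1`, has not yet been tested in this assay. It differs from compound 1 in one place: (1-phenylethyl)amino in place of (methylsulfonyl)oxy on an aromatic carbon. Compound 4 thus carries an amino substituent on the shared core, as compound 3 does with its own amino substituent, and compound 3 gives 4000 nM.

Among the compounds with values here, no step between measured compounds is known here, so the size of the change must be guessed. Compound 1 gives only a limit. Any real number for compound 4 would therefore mean stronger inhibition beyond the usual scatter. The step from compound 1 to compound 4 is estimated at an at least 3.3-fold lower number from compound 1 to compound 4 (0.52 log units; beyond the scatter). Compound 4 is expected to give 6000 nM, with a range from 1500 nM to 20000 nM, though a limit instead of a number remains possible.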

Compound 4, half-maximal inhibitory concentration: > 20000 nM
Compound 4: no number, only a limit; the forecaster's own chance of this, stated with the estimate: 35%; at least 3.3-fold (0.52 log units) between middle value and limit.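

In this assay compound 4 gives > 20000 nM as a limit of the assay. Within the data shown here, compound 1 gives > 20000 nM as a limit too, so no step from one to the other can be read. The compounds shown leave open how strongly either inhibits, and whether (1-phenylethyl)amino and (methylsulfonyl)oxy differ here at all. Compound 4 thus joins the values at the limit: the limit of > 20000 nM in this assay, at which 3 of the 4 values shown sit.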